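Inverting One Stereocentre of Compound 3

The compounds below may be only part of what the source reports. "The series", "measured", "known", "first", "only" and "open" are said of these compounds alone.

In an ADME assay on Vero cells (Chlorocebus sabaeus) for cytotoxicity (on this read-out lower numbers stand for stronger inhibition and higher numbers for weaker inhibition), compound 3 `OC[C@@H]1C=C(F)[C@H](n2cnc3c(O)ncnc32)O1` gives 87700 nM. Compound 1 `Nc1nc(F)nc2c1ncn2[C@H]1O[C@H](CO)C=C1F` gives 16100 nM, a lower number by more than the scatter, so compound 3 holds the higher of the two exact values. Compound 2 `Nc1ncnc2c1ncn2[C@@H]1O[C@H](CO)C=C1F` reads > 100000 nM, which is a limit of the assay and not a number.

Compound 4 `OC[C@@H]1C=C(F)[C@@H](n2cnc3c(O)ncnc32)O1` departs from compound 3 in one respect only: the two compounds have the same atoms and bonds and differ only in configuration as drawn: 1 of 2 stereo elements differ; a stereocentre at a saturated ring carbon is drawn R in compound 3 and S in compound 4. A stereocentre at a saturated ring carbon is thus drawn R in compound 3 and S in compound 4. Within the data shown here, no measured step changes configuration alone. Among the measured compounds shown here, the one measured step, an at least 1.1-fold lower number from compound 2 to compound 3 (0.05 log units; that floor lies within the scatter), puts hydroxy in place of amino on an aromatic carbon, and its floor lies within the scatter, so it gives only weak guidance. No shift beyond the scatter is therefore expected in this assay, although a lower number remains possible. The expected change is a 1.1-fold lower number from compound 3 to compound 4 (0.04 log units; within the scatter). For compound 4 the estimated value is 80000 nM, with an expected range from 30000 nM to 130000 nM.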

Compound 4, half-maximal inhibitory concentration: > 100000 nM
Compound 4 was reported as a limit; the forecaster's own chance of this, stated with the estimate: 45%; middle value at least 1.2-fold (0.09 log units) from the limit.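

In this assay, inverting this stereocentre at a saturated ring carbon, with nothing entering or leaving, gives an at least 1.1-fold higher number from compound 3 to compound 4 (0.05 log units; that floor lies within the scatter), the first step shown that isolates configuration: the fact that compounds 3 and 4 differ only in the configuration as drawn Compound 4 reads > 100000 nM, which is a limit of the assay and not a number. The inversion therefore shows no drop in the number, but its true size cannot be read, and the step shows only a floor: the limit of > 100000 nM in this assay, at which 2 of the 4 values shown sit.

From the compounds shown here alone, how far compound 4 actually lies from compound 3 remains open, as does whether the other configuration at this stereocentre would matter with a different group on the aromatic carbon. A thiol or a methoxy group in place of hydroxy there could show whether the same inversion gives a shift beyond the scatter.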